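The source may hold more compounds than are shown below. What is called first, only, known or untested is meant among the compounds shown, and "the series" means these compounds.

Measured in a functional assay on A-375 cells (Homo sapiens) for cytotoxicity, read by MTT assay, with a stated time of 72 h; on this read-out lower numbers stand for stronger inhibition and higher numbers for weaker inhibition:
- compound 1 `O=C1c2c[n+]([O-])c3ccccc3c2C(=O)c2c1c1ccccc1n2Cc1cn(C[C@H](O)CO)nn1`: 350 nM
- compound 2 `CC1(C)OCC(Cn2cc(Cn3c4c(c5ccccc53)C(=O)c3c[n+]([O-])c5ccccc5c3C4=O)nn2)O1`: 330 nM
- compound 3 `O=C1c2c[n+]([O-])c3ccccc3c2C(=O)c2c1c1ccccc1n2Cc1cn(CC(O)CO)nn1`: 440 nM

The value of compound 3 lies within the scatter of both other compounds. Compound 4 `CC1(C)OC[C@@H](Cn2cc(Cn3c4c(c5ccccc53)C(=O)c3c[n+]([O-])c5ccccc5c3C4=O)nn2)O1` differs from compound 3 by having 2,2-dimethyl-1,3-dioxolan-4-yl in place of 1,2-dihydroxyethyl (2,2-dimethyl-1,3-dioxolan-4-yl in place of 1,2-dihydroxyethyl on a saturated chain carbon bound to an aromatic nitrogen). The same exchange appears as a 1.1-fold lower number from compound 1 to compound 2 (0.03 log units; within the scatter) and, in reverse, as a 1.3-fold higher number from compound 2 to compound 3 (0.12 log units; within the scatter), both within the scatter. Also relevant is the fact that one of compounds 1 and 3 is drawn with a defined configuration and the other without, at the place where they differ, which goes with a 1.3-fold higher number from compound 1 to compound 3 (0.10 log units; within the scatter), again within the scatter. No change beyond the scatter is therefore expected in this assay. The expected step is a 1.3-fold lower number from compound 3 to compound 4 (0.10 log units; within the scatter). For compound 4 the estimated value is 350 nM, with an expected range from 210 nM to 580 nM.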

Compound 4, half-maximal inhibitory concentration: 450 nM
For compound 4 the middle estimate is 1.3-fold (0.11 log units) below the measured one; low and high end bracket the measured number.
By their numbers in this assay, from the lowest: compounds 2, 1, 3 and 4 (each within the scatter of the next).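

In this assay the exchange of 1,2-dihydroxyethyl for 2,2-dimethyl-1,3-dioxolan-4-yl stays within the scatter once more, now with a defined configuration in the entering ring (a 1.0-fold higher number from compound 3 to compound 4 (0.01 log units; within the scatter); a 1.3-fold higher number from compound 1 to compound 4 (0.11 log units; within the scatter)). Among these compounds, the same holds at the saturated ring carbon, a stereocentre the earlier compounds did not compare (a 1.4-fold higher number from compound 2 to compound 4 (0.13 log units; within the scatter)), where the only difference is this: the fact that one of compounds 2 and 4 is drawn with a defined configuration and the other without, at the place where they differ. From the compounds shown here alone, whether an amine, a carboxylic acid or a longer chain at this place would move the number beyond the scatter remains open. So does the effect of the opposite configuration at either stereocentre.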